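The compounds below may be only part of what the source reports. "The series", "measured", "known", "first", "only" and "open" are said of these compounds alone.

Compound 2 `CCCCCCNC(=O)n1cc(C(F)(F)F)c(=O)[nH]c1=O` is the strongest inhibitor among the three compounds measured in an assay on HEK293 cells for inhibition of acid ceramidase (Rattus norvegicus), read by LC-MS, with a stated time of 30 min (a lower number here means a stronger inhibitor, a higher number a weaker inhibitor), where compound 2 gives 12 nM. Its two neighbours differ from it only in the group on the aromatic carbon: compound 1 `CCCCCCNC(=O)n1cc(C)c(=O)[nH]c1=O`, carrying a methyl there, gives 1460 nM in this assay, and compound 3 `CCCCCCNC(=O)n1cc(N2CCN(C)CC2)c(=O)[nH]c1=O`, carrying a 4-methylpiperazin-1-yl, gives 1400 nM. The step of a 120-fold lower number from compound 1 to compound 2 (2.09 log units; beyond the scatter) and the step of a 120-fold higher number from compound 2 to compound 3 (2.07 log units; beyond the scatter) are both large, while the step of a 1.0-fold lower number from compound 1 to compound 3 (0.02 log units; within the scatter) lies within the scatter, so a methyl and a 4-methylpiperazin-1-yl at this carbon come out alike and only the trifluoromethyl stands apart.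

Compound 4 `CCCCCCNC(=O)n1cc(NC)c(=O)[nH]c1=O` takes the same step away from the trifluoromethyl: methylamino in place of trifluoromethyl on an aromatic carbon. Among the compounds with values here, the two measured steps that bear on this change both point one way: leaving the trifluoromethyl for methyl cost roughly as much as leaving it for the much bulkier 4-methylpiperazin-1-yl, and nothing measured so far shows that the kind of group which replaces it matters. For compound 4 a large loss of potency is therefore expected, with the step of a 100-fold higher number from compound 2 to compound 4 (2.00 log units; beyond the scatter) estimated to resemble those two measured losses. The expected value for compound 4 in this assay is 1200 nM, with a range from 300 nM to 5000 nM.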

Compound 4, half-maximal inhibitory concentration: 3400 nM
Compound 4: middle estimate off by 2.8-fold (0.45 log units), on the low side, and the stated range covers the measured number.
By their numbers in this assay, from the lowest: compound 2; then compounds 3 and 1 (each within the scatter of the next); then compound 4.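

In this assay the methylamino group gives the large step of a 280-fold higher number from compound 2 to compound 4 (2.45 log units; beyond the scatter), which confirms that the potency of compound 2 is lost when this trifluoromethyl is replaced by a group carrying a nitrogen on the aromatic carbon. The new information lies among the weaker compounds, where the modest steps of a 2.3-fold higher number from compound 1 to compound 4 (0.37 log units; beyond the scatter) and a 2.4-fold higher number from compound 3 to compound 4 (0.39 log units; beyond the scatter) make compound 4 the weakest of the four and show that the replacing group does matter, although far less than leaving the trifluoromethyl does. Methyl and 4-methylpiperazin-1-yl therefore do not mark a shared floor for this position, and the methylamino group, which brings a hydrogen-bond donor and a hydrogen-bond acceptor that the trifluoromethyl lacks, falls on the weaker side of both.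

No supporting measurement accounts for the difference between these groups. From the compounds shown here alone, whether a chlorine, a nitrile or a pentafluoroethyl at this carbon would keep the potency of compound 2, and whether a dimethylamino group would behave like methylamino, remains open.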